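The compounds below may be only part of what the source reports. "The series", "measured", "known", "first", "only" and "open" are said of these compounds alone.

Measured compounds:
compound 1 `O=C(CSC(=S)N[C@H]1CCOC1=O)Nc1ccc(Br)cc1` — 28300 nM
compound 2 `Cc1ccc(NC(=O)CSC(=S)N[C@H]2CCOC2=O)cc1` — 32700 nM
compound 3 `CCOC(=O)c1ccc(NC(=O)CSC(=S)N[C@H]2CCOC2=O)cc1` — 64900 nM

In a functional assay on SMMC-7721 cells (Homo sapiens) for cytotoxicity, read by MTT assay, with a stated time of 72 h (a higher number here means a weaker inhibitor, a lower number a stronger inhibitor), compound 3 stands highest of the three numbers. Its gap to compound 2 is small, a 2.0-fold higher number from compound 2 to compound 3 (0.30 log units; within the scatter); its gap to compound 1 is larger, a 2.3-fold higher number from compound 1 to compound 3 (0.36 log units; beyond the scatter). The step from compound 1 to compound 2 is also small, a 1.2-fold higher number from compound 1 to compound 2 (0.06 log units; within the scatter).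

Compound 4 `O=C(CSC(=S)N[C@H]1CCOC1=O)Nc1ccc(C(=O)/C=C/c2ccccc2Cl)cc1` is obtained from compound 3 by 2-(2-chlorophenyl)ethenyl in place of ethoxy on a carbonyl carbon. The three measured steps all alter the substituent on the aromatic carbon and leave the carbonyl carbon untouched, so none bears directly on this change; they show only that variation at the aryl substituent has so far moved this assay by modest amounts at most. Within the data shown here, with no measured step at the carbonyl carbon, a large shift in this assay cannot be anticipated from these data, and compound 4 is expected to sit near compound 3, with a wide range allowed. The step from compound 3 to compound 4 is estimated at a 1.9-fold lower number from compound 3 to compound 4 (0.27 log units; within the scatter). Compound 4 is therefore expected to give 35000 nM in this assay, with a range from 9000 nM to 130000 nM.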

Compound 4, half-maximal inhibitory concentration: 20400 nM
Beside the measured number, compound 4's estimate is 1.7-fold (0.23 log units) above it, and the stated range covers the measured number.
By their numbers in this assay, from the lowest: compounds 4, 1, 2 and 3 (each within the scatter of the next, the first and the last beyond it).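

Among these compounds, at the carbonyl carbon whose other neighbour is an aromatic carbon, 2-(2-chlorophenyl)ethenyl in place of ethoxy gives in this assay a 3.2-fold lower number from compound 3 to compound 4 (0.50 log units; beyond the scatter) as the first measured step at this place, the earlier steps having all changed the substituent on the aromatic carbon. This place therefore accepts a larger group, with a six-membered aromatic ring of carbon only and a double bond outside aromatic rings, and the number falls rather than rises. No measurement available here accounts for the step.

Which part of the entering group carries the step stays open, whether the chlorine, the double bond or the aromatic ring. A 2-phenylethenyl group without chlorine, a saturated 2-(2-chlorophenyl)ethyl chain, or an amine on the same carbonyl carbon would separate these parts.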